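This account rests on a few compounds, and the source may have more. Where it says the series, first, only, none or still open, it means among the compounds named here.

Compound 1 `CCN1CCN(c2ccc(S(=O)(=O)Oc3ccccc3OC)cc2)C1=O`: > 100000 nM
Compound 2 `CCCN1CCN(c2ccc(S(=O)(=O)Oc3ccccc3OC)cc2)C1=O`: > 100000 nM
Compound 3 `CCCCN1CCN(c2ccc(S(=O)(=O)Oc3ccccc3)cc2)C1=O`: > 100000 nM

All three compounds were tested in a functional assay on HT-29 cells (Homo sapiens) for antiproliferative activity, read by sulforhodamine B assay, with a stated time of 48 h (on this read-out higher numbers stand for weaker inhibition and lower numbers for stronger inhibition), and none gave a number. Compound 3 gives only a limit, > 100000 nM. The whole set rests at the limit of > 100000 nM in this assay, at which 3 of the 3 values shown sit.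

Compound 4 `CCCCN1CCN(c2ccc(S(=O)(=O)Oc3ccccc3OC)cc2)C1=O` differs from compound 3 in one place: methoxy in place of hydrogen on an aromatic carbon. The methoxy takes the place of a hydrogen on an aromatic carbon, ortho to a large group.

Within the data shown here, no measured step covers this exchange. Among the measured compounds shown here, the one step available, a step that the two limits leave unreadable from compound 1 to compound 2, concerns the chain and shows no size. Compound 1 already carries the 2-methoxyphenoxy group and still gives a limit, > 100000 nM. Compound 2 carries the same group and also gives a limit, > 100000 nM.

On this basis, no readable step in either direction is expected in this assay, and a further limit is the likely report. The estimated change is a number no higher from compound 3 to compound 4 (the limit leaves the size open). For compound 4 the expected value is 100000 nM, with an estimated range of 30000 nM to 300000 nM.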

Compound 4, half-maximal inhibitory concentration: > 100000 nM
Compound 4: a limit, no number; the forecaster's own chance of this, stated with the estimate: 75%; the middle value sits exactly at the limit.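

In this assay compound 4 gives > 100000 nM, a limit and not a number. Among these compounds, no step from compound 1, compound 2 or compound 3 to compound 4 can be read: the limit of > 100000 nM in this assay, at which 4 of the 4 values shown sit. The compounds shown leave open whether the methoxy group or the chain changes the read-out at all.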